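Changing the aromatic ring on the amide carbonyl

The source may hold more compounds than are shown below. What is called first, only, known or untested is meant among the compounds shown, and "the series" means these compounds.

Compound 1 `O=C(NC1CCN(Cc2ccc3ccccc3c2)CC1)c1ccc(F)cc1` gives 36 nM in an assay on isolated protein for binding affinity to melanin-concentrating hormone receptor 1 (Homo sapiens); a lower number here means a stronger inhibitor, a higher number a weaker inhibitor. Adding a methoxy group gives compound 2 `COc1cc(C(=O)NC2CCN(Cc3ccc4ccccc4c3)CC2)ccc1F`, which gives 13 nM in this assay; the move a 2.8-fold lower number from compound 1 to compound 2 (0.44 log units; beyond the scatter) is the only step measured so far, and it leaves compound 2 with the lowest of the two numbers, its nearest neighbour being compound 1. Compound 3 `CN(C)c1cccc(C(=O)NC2CCN(Cc3ccc4ccccc4c3)CC2)c1` takes a larger step: 3-(dimethylamino)phenyl in place of 4-fluoro-3-methoxyphenyl on a carbonyl carbon. The methoxy group that arrived between compound 1 and compound 2 is removed again, together with the fluorine, and a dimethylamino group enters instead. Among the measured compounds shown here, only the step from compound 1 to compound 2 bears on this change, and only in part, because a 2.8-fold lower number from compound 1 to compound 2 (0.44 log units; beyond the scatter) covers the methoxy alone. With that group gone, a modest rise in the number is expected for compound 3, a 2.3-fold higher number from compound 2 to compound 3 (0.36 log units; beyond the scatter). For compound 3 the estimate in this assay is 30 nM, within a range from 8 nM to 120 nM.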

Compound 3, inhibition constant: 125 nM
Beside the measured number, compound 3's estimate is 4.2-fold (0.62 log units) below it; the whole stated range lies below it.
By their numbers in this assay, from the lowest: compound 2; then compound 1; then compound 3.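

In this assay, 3-(dimethylamino)phenyl on the carbonyl carbon gives a 9.6-fold higher number from compound 2 to compound 3 (0.98 log units; beyond the scatter) and a 3.5-fold higher number from compound 1 to compound 3 (0.54 log units; beyond the scatter), so this position does respond to the choice of ring substituents, even though the entering and leaving groups have the same heavy-atom count. Losing the methoxy group cannot account for the whole result, since compound 3 also gives a higher number than compound 1, which has no methoxy group. Nothing measured here explains this rise in the number.

Compound 1 and compound 3 differ in both the fluorine and the dimethylamino group, so the share of each in that step remains unresolved. Going by these compounds, it also remains open how a primary amine or a carboxylic acid in place of the dimethylamino group would read in this assay.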